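Swapping methoxy for fluoro: a second look at cytotoxicity

The compounds below may be only part of what the source reports. "The series", "measured", "known", "first", "only" and "open" are said of these compounds alone.

Of the compounds shown here, three have been measured in an ADME assay on HEp-2 cells (Homo sapiens) for cytotoxicity, read by MTT assay, with a stated time of 3 days; a lower number here means that less compound is tolerated, a higher number that more compound is tolerated. Compound 1 `CC[C@@H](CCn1cncn1)c1ccc(F)cc1` gives 90.3 ug/mL. Compound 2 `CC[C@@H](CCn1cncn1)c1ccc(OC)cc1` gives 146 ug/mL. Compound 3 `CCCC[C@H](CCn1cncn1)c1ccc(OC)cc1` gives 34.5 ug/mL, the lowest of the three, so that less of it is tolerated than of compound 1 or compound 2.

Compound 1 and compound 2 differ in one place: fluoro in place of methoxy on an aromatic carbon. That change produced a 1.6-fold lower number from compound 2 to compound 1 (0.21 log units; within the scatter), a step that does not exceed the usual variation of the measurement. How the core of compound 3 differs from that of compound 2 is not broken down here.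

Compound 4 `CCCC[C@H](CCn1cncn1)c1ccc(F)cc1` has not been measured in this assay . It differs from compound 3 by the same change: fluoro in place of methoxy on an aromatic carbon. Because the same change gave a 1.6-fold lower number from compound 2 to compound 1 (0.21 log units; within the scatter), compound 4 is expected to show a small step, a 1.4-fold lower number from compound 3 to compound 4 (0.14 log units; within the scatter). Compound 4 is therefore estimated at 25 ug/mL, most likely between 12 ug/mL and 50 ug/mL.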

Compound 4, half-maximal cytotoxic concentration: 38.5 ug/mL
Beside the measured number, compound 4's estimate is 1.5-fold (0.19 log units) below it, within the range that was stated.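

In this assay, putting fluoro in place of methoxy gave a 1.1-fold higher number from compound 3 to compound 4 (0.05 log units; within the scatter), a step too small to tell the two compounds apart. Set beside the earlier case, the change behaves alike on both cores, and the two steps cannot be separated from each other: the same change on two cores in this assay, a 1.6-fold lower number (0.21 log units; within the scatter) from compound 2 to compound 1 and a 1.1-fold higher number (0.05 log units; within the scatter) from compound 3 to compound 4, 1.8-fold (0.26 log units) apart, within the scatter of two such steps. Among these compounds, on these two cores, then, the swap leaves the tolerated concentration much where it was, but this rests on only two pairs of compounds, so it does not show that the same would hold on a further core, and it does not explain why the number barely moves.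

The compounds shown carry only methoxy or fluoro on that aromatic carbon, so it stays open how an amine, a carboxylic acid or a nitrile in the same place would compare. As far as these compounds go, it also stays open whether the swap would remain this small on a core with a longer chain, such as hexyl.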